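Methylpyridyl isomer swap on a shared core

A few compounds are considered here, and "the series" means these few. Any claim that something is new, unique, unknown or untested is made for them only; others in the source may bear on it.

Of the compounds shown here, three carry a number so far. In a physicochemical assay for lipophilicity, read by HPLC, at pH 7.5 (a lower number here means a more polar compound, a higher number a more lipophilic compound), compound 1 `CC[C@@H](Nc1c(C#N)c(-c2ccc(-c3ncccc3C)cc2)nc2cnccc12)C(N)=O` gives 2. Compound 3 `CC(C)(CC(N)=O)c1c(C#N)c(-c2ccc(Br)cc2)nc2cnccc12` gives 2.1 in this assay, and compound 2 `CCOc1ccccc1-c1ccc(-c2nc3cnccc3c(N[C@H](CC)C(=O)NS(C)(=O)=O)c2C#N)cc1` gives 2.2. Compound 1 has the lowest of the three numbers, yet its gap to compound 3 and its gap to compound 2 both lie within the scatter, so the three cannot be ranked on these data. Within the data shown here, no two measured compounds differ in a single place, so there is no measured step to lean on.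

Compound 4 `CC[C@@H](Nc1c(C#N)c(-c2ccc(-c3cccnc3C)cc2)nc2cnccc12)C(N)=O` has not been measured. Against compound 1 the difference is 2-methylpyridin-3-yl in place of 3-methylpyridin-2-yl on an aromatic carbon. The two have the same atoms, joined differently; the group that leaves and the group that enters carry the same counts, and the attachment point on the aromatic carbon, para to a large group, is unchanged. With no hydrogen-bond donor or acceptor gained or lost, the expected step in this assay is none beyond the scatter, in either direction; the step from compound 1 to compound 4 is estimated at no change at the digits printed from compound 1 to compound 4 (within the scatter). Compound 4 is therefore expected to give 2 in this assay, with a range of 1.7 to 2.3.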

Compound 4, distribution coefficient: 1.9
Compound 4: the middle estimate sits 0.10 log units above what was measured; the range from low to high includes it.
By their numbers in this assay, from the lowest: compounds 4, 1, 3 and 2 (each within the scatter of the next).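

This pair gives the series its first measured step in a single place: exchanging 3-methylpyridin-2-yl for 2-methylpyridin-3-yl on an aromatic carbon, para to a large group, reads in this assay as a number 0.10 log units lower from compound 1 to compound 4 (within the scatter). Among these compounds, at this position, then, two isomers with the same atoms and the same counts of hydrogen-bond donors and acceptors are not separated by this read-out, something the earlier compounds, which differ from each other in more than one place, could not show. No measurement shown bears on the cause of this result.

From the compounds shown here alone, one isomer swap says little about the position as a whole, so it remains open whether a group built from other atoms in this place, such as a phenyl ring carrying a carboxylic acid or an aminomethyl group, would give a step beyond the scatter in this assay. Going by these compounds, it also remains open whether the same swap would read alike with a carboxylic acid in place of the primary amide of compound 1.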